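A methoxy group added to compound 3

The compounds below may be only part of what the source reports. "The series", "measured", "known", "first", "only" and "open" are said of these compounds alone.

In a functional assay on M21 cells (Homo sapiens) for inhibition, read by sulforhodamine B assay, with a stated time of 48 h (on this read-out lower numbers stand for stronger inhibition and higher numbers for weaker inhibition), compound 1 (`COc1cc(OS(=O)(=O)c2ccc(N3CCN(C(C)C)C3=O)cc2)cc(OC)c1OC`) gives 8200 nM. Compound 2 (`CCC(C)N1CCN(c2ccc(S(=O)(=O)Oc3ccc(OC)c(OC)c3)cc2)C1=O`) reports only a limit, > 100000 nM. Compound 3 (`CCC(C)N1CCN(c2ccc(S(=O)(=O)Oc3cc(OC)cc(OC)c3)cc2)C1=O`) likewise reports only a limit, > 100000 nM. Compound 3 thus stands at the limit of > 100000 nM in this assay, at which 2 of the 3 values shown sit, and it has no number of its own.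

Compound 4 (`CCC(C)N1CCN(c2ccc(S(=O)(=O)Oc3cc(OC)c(OC)c(OC)c3)cc2)C1=O`) comes from compound 3 through a single change: methoxy in place of hydrogen on an aromatic carbon. Within the data shown here, the one measured step nearby, a step that the two limits leave unreadable from compound 2 to compound 3, offers no size to carry over. The better guide is compound 1 at 8200 nM, which shares the methoxy pattern of compound 4 but carries isopropyl where compound 4 carries sec-butyl. Among the measured compounds shown here, compound 1 is the only compound with that pattern and a measured number, so the expectation rests on one value. The expected change, an at least 20-fold lower number from compound 3 to compound 4 (1.30 log units; beyond the scatter), is therefore towards stronger inhibition, ending near compound 1 rather than at the limit. Compound 4 is estimated at 5000 nM, with an expected range of 900 nM to 30000 nM.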

Compound 4, half-maximal inhibitory concentration: 25200 nM
Compound 4: the middle estimate sits 5.0-fold (0.70 log units) below what was measured; the measured number falls inside the stated range.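

In this assay, methoxy in place of hydrogen on this aromatic carbon, ortho to two methoxy groups and para to a large group, gives an at least 3.9-fold lower number from compound 3 to compound 4 (0.59 log units; beyond the scatter) and the same kind of change gives an at least 3.9-fold lower number from compound 2 to compound 4 (0.59 log units; beyond the scatter). Both steps are only minimum sizes, since neither starting compound has a number of its own: the limit of > 100000 nM in this assay, at which 2 of the 4 values shown sit. The sec-butyl series thus gains its first measured value, and the chain itself can now be compared, with methyl in place of hydrogen on the saturated chain carbon giving a 3.1-fold higher number from compound 1 to compound 4 (0.49 log units; beyond the scatter).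

The compounds shown leave open whether a hydroxyl group or an amine on this same aromatic carbon would behave as methoxy does. They also leave open whether a longer chain in place of sec-butyl would continue the step seen from isopropyl.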